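The source may report more compounds than this note shows. Statements on the series, on what has been measured and on what is new or still open speak of the compounds shown alone.

Working notes on the series.

Compound 1 `CCn1c(C(=O)NCC#N)ccc1C(CC)(CC)c1ccc(OCCC(O)(CC)CC)c(C)c1` and compound 2 `CCn1c(C(=O)N(C)CC(=O)O)ccc1C(CC)(CC)c1ccc(OCCC(O)(CC)CC)c(C)c1` share one core and differ only at the amide. In an assay on cells for agonist activity at vitamin D3 receptor (Homo sapiens), with a stated time of 96 h (on this read-out higher numbers stand for an effect only at larger amounts of compound and lower numbers for an effect already at smaller amounts), compound 1 gives 1080 nM, the highest of the two numbers; compound 2 gives 89 nM. For the measured compounds named here, the one measured step, a 12-fold lower number from compound 1 to compound 2 (1.08 log units; beyond the scatter), shows that changing the group on the amide nitrogen can move this read-out a long way.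

Compound 3 `CCn1c(C(=O)NC(CO)CCO)ccc1C(CC)(CC)c1ccc(OCCC(O)(CC)CC)c(C)c1` is not yet measured. It differs from compound 1 as follows: 3-hydroxy-1-(hydroxymethyl)propyl in place of cyanomethyl on an amide-type nitrogen. Going by the values given here, only the step from compound 1 to compound 2 bears on this, and it replaces the same cyanomethyl with a different group, so it sets the scale rather than the direction. The expected step is a 2.7-fold lower number from compound 1 to compound 3 (0.43 log units; beyond the scatter), a gain beyond the scatter that is expected to be smaller than the measured step. For compound 3 in this assay the expected value is 400 nM, with a range from 100 nM to 1500 nM.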

Compound 3, half-maximal effective concentration: 2490 nM
Estimate against measurement, compound 3: 6.2-fold (0.79 log units) below; the measured number lies above the stated range.
By their numbers in this assay, from the lowest: compound 2; then compound 1; then compound 3.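

In this assay, 3-hydroxy-1-(hydroxymethyl)propyl in place of cyanomethyl on an amide-type nitrogen gives a 2.3-fold higher number from compound 1 to compound 3 (0.36 log units; beyond the scatter) and so shows that this position can also move the number upward, whereas the earlier step moved it downward. The comparison with the group of compound 2 gives a 28-fold higher number from compound 2 to compound 3 (1.45 log units; beyond the scatter) and shows that the position spans a wide range among these three compounds. Among them, the lowest number belongs to the only group carrying a carboxylic acid. Nothing available explains these differences.

The compounds shown leave open whether the carboxylic acid or the methyl on the amide nitrogen of compound 2 accounts for its lower number. They also leave open how a simple 2-hydroxyethyl chain or an amine would behave at this position.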